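Chloro Removal and Cell Cytotoxicity in Two Related Series

The source may hold more compounds than are shown below. What is called first, only, known or untested is meant among the compounds shown, and "the series" means these compounds.

Compound 1 `CNC(=O)c1cc(Oc2ccc(NC(=O)c3nccc(-c4ccccc4)n3)cc2)ccn1` and compound 2 `CNC(=O)c1cc(Oc2ccc(NC(=O)c3nccc(-c4cccc(Cl)c4)n3)cc2)ccn1` share one core; compound 3 `CNC(=O)c1cc(Oc2ccc(NC(=O)c3cc(-c4ccc(Cl)cc4)ncn3)cc2)ccn1` and the unmeasured compound 4 `CNC(=O)c1cc(Oc2ccc(NC(=O)c3cc(-c4ccccc4)ncn3)cc2)ccn1` share another, and the difference between the two cores is not broken down here. In a functional assay on A549 cells (Homo sapiens) for cytotoxicity, read by MTT assay, with a stated time of 72 h (a lower number here means a stronger inhibitor, a higher number a weaker inhibitor), compound 1 gives 26200 nM. For compound 2 this assay reports only a limit, > 100000 nM. The change hydrogen in place of chloro on an aromatic carbon thus brings an at least 3.8-fold lower number from compound 2 to compound 1 (0.58 log units; beyond the scatter), and its size is known only as a bound because the limit of > 100000 nM in this assay, at which 2 of the 3 values shown sit, caps what compound 2 can show. For compound 3 this assay likewise reports only a limit, > 100000 nM. The change hydrogen in place of chloro on an aromatic carbon is the same kind of change, though here the chloro sits para to a large group rather than meta to a large group. A similar gain is expected from this change, an at least 2.0-fold lower number from compound 3 to compound 4 (0.30 log units; that floor lies within the scatter), resting on an at least 3.8-fold lower number from compound 2 to compound 1 (0.58 log units; beyond the scatter). Compound 4 is estimated at 50000 nM, roughly between 15000 nM and 150000 nM, with a fair chance that only a limit is reported again.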

Compound 4, half-maximal inhibitory concentration: 27100 nM
The estimate for compound 4 lay 1.8-fold (0.27 log units) above the measured number; the measured number falls inside the stated range.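

In this assay, replacing 4-chlorophenyl with phenyl brings an at least 3.6-fold lower number from compound 3 to compound 4 (0.56 log units; beyond the scatter). The change therefore points the same way on both cores, so its direction carries from one core to the other in these two pairs: the same change on two cores in this assay, an at least 3.8-fold lower number (0.58 log units; beyond the scatter) from compound 2 to compound 1 and an at least 3.6-fold lower number (0.56 log units; beyond the scatter) from compound 3 to compound 4; the limit leaves it open whether they differ Compound 2 and compound 3 are each reported only as a limit, so the full size of neither step is known, and equal gains on the two cores are not shown: the limit of > 100000 nM in this assay, at which 2 of the 4 values shown sit.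

The compounds shown leave open whether a fluoro, a methoxy or an amine in place of the chloro would give a number like that of hydrogen. They also leave open whether the same step would hold on any core beyond these two.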